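Chloroacetyl urea to chloroalkyl amide on the benzyl core

A few compounds are considered here, and "the series" means these few. Any claim that something is new, unique, unknown or untested is made for them only; others in the source may bear on it.

Two compounds of this series have been run in a functional assay on HT-29 cells (Homo sapiens) for antiproliferative activity, with a stated time of 48 h; a higher number here means a weaker inhibitor, a lower number a stronger inhibitor. Compound 1 `CC(C)(C)c1ccc(CNC(=O)NC(=O)CCl)cc1` gives 7100 nM in this assay, and compound 2 `CCCCC(OC)c1cccc(NC(=O)NC(=O)CCl)c1` gives 10000 nM; the two numbers sit within the scatter of each other, so neither can be called the stronger inhibitor, and compound 1 simply holds the lower of the two numbers shown. Going by the values given here, no step between measured compounds that differ in one place is available, so no size of effect for any single change has yet been seen.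

Compound 3 `CC(C)(C)c1ccc(CNC(=O)CCCl)cc1` is the next candidate for this assay. Relative to compound 1 it carries 2-chloroethyl in place of ((chloromethyl)carbonyl)amino on a carbonyl carbon, that is, 2-chloroethyl in place of ((chloromethyl)carbonyl)amino on a carbonyl carbon. Nothing in the measured pair bears on this change. The step is estimated as a 2.5-fold higher number from compound 1 to compound 3 (0.40 log units; beyond the scatter), toward a higher number. Compound 3 is therefore estimated at 18000 nM in this assay, with a range from 6000 nM to 50000 nM.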

Compound 3, half-maximal inhibitory concentration: 87000 nM
Compound 3: the middle estimate sits 4.8-fold (0.68 log units) below what was measured; measured number outside the range, above it.
By their numbers in this assay, from the lowest: compounds 1 and 2 (each within the scatter of the next); then compound 3.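

In this assay, going by these compounds alone, 2-chloroethyl in place of ((chloromethyl)carbonyl)amino on a carbonyl carbon gives a 12-fold higher number from compound 1 to compound 3 (1.09 log units; beyond the scatter), the only single-place change so far and a large one. This position is therefore not indifferent to the group it carries: the group that leaves, with 5 heavy atoms, 1 hydrogen-bond donor and 1 hydrogen-bond acceptor, cannot be exchanged for 2-chloroethyl, with 3 heavy atoms and neither donor nor acceptor, without a clear rise in the number. No measurement in hand accounts for the size of this step, so it stands as an observation on this one pair.

The change replaces the whole group at once, so the compounds shown do not separate the contribution of the nitrogen and the second carbonyl from that of the chain carrying the chlorine. Still open, from the compounds shown here alone, is how a plain ethyl group or a longer 3-chloropropyl chain on this carbonyl carbon would read in this assay, and whether 2-chloroethyl would produce a step of similar size on the core of compound 2.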